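From naphthalen-2-yl to 4-bromophenyl: notes on the series

The source may hold more compounds than are shown below. What is called first, only, known or untested is meant among the compounds shown, and "the series" means these compounds.

compound 1 (`COc1ccc(/C=C/C(=O)c2ccc(Nc3cc(C)nc4nc(SCc5nc6ccccc6[nH]5)nn34)cc2)cc1F`): 140 nM
compound 2 (`COc1ccc(/C=C/C(=O)c2ccc(Nc3cc(C)nc4nc(SCc5nc6ccccc6[nH]5)nn34)cc2)cc1`): 170 nM
compound 3 (`Cc1cc(Nc2ccc(C(=O)/C=C/c3ccc4ccccc4c3)cc2)n2nc(SCc3nc4ccccc4[nH]3)nc2n1`): 5 nM

In a functional assay on SW-620 cells (Homo sapiens) for cytotoxicity, read by MTT assay, with stated times of 4 h and 72 h, tested at 2 uM (on this read-out lower numbers stand for stronger inhibition and higher numbers for weaker inhibition), compound 3 gives 5 nM as the lowest of the three numbers. The change to compound 4 (`Cc1cc(Nc2ccc(C(=O)/C=C/c3ccc(Br)cc3)cc2)n2nc(SCc3nc4ccccc4[nH]3)nc2n1`) is 4-bromophenyl in place of naphthalen-2-yl (4-bromophenyl in place of naphthalen-2-yl on a double-bonded chain carbon bound to a double-bonded chain carbon). Two large measured steps bear on it, a 28-fold lower number from compound 1 to compound 3 (1.45 log units; beyond the scatter) and a 34-fold lower number from compound 2 to compound 3 (1.53 log units; beyond the scatter) with naphthalen-2-yl entering each time. Hydrogen in place of fluoro gave only a 1.2-fold higher number from compound 1 to compound 2 (0.08 log units; within the scatter) and stays within the scatter. Among the compounds with values here, no compound carrying bromine has been measured. The expected step in this assay is an 8.0-fold higher number from compound 3 to compound 4 (0.90 log units; beyond the scatter) toward a higher number, estimated as smaller than those two large steps. Compound 4 is estimated at 40 nM (expected range 10 nM to 160 nM).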

Compound 4, half-maximal inhibitory concentration: 290 nM
For compound 4 the middle estimate is 7.3-fold (0.86 log units) below the measured one, outside the stated range (above it).
By their numbers in this assay, from the lowest: compound 3; then compounds 1, 2 and 4 (each within the scatter of the next, the first and the last beyond it).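

In this assay, replacing the two rings of naphthalen-2-yl with the single ring of 4-bromophenyl gives up the low number of compound 3: a 58-fold higher number from compound 3 to compound 4 (1.76 log units; beyond the scatter). The bromo group also leaves compound 4 close to the other single-ring compounds, with a 1.7-fold higher number from compound 2 to compound 4 (0.23 log units; within the scatter) and a modest 2.1-fold higher number from compound 1 to compound 4 (0.32 log units; beyond the scatter), so among these four only naphthalen-2-yl stands apart. Nothing available explains this gap.

Going by these compounds, it remains open whether quinolin-3-yl or naphthalen-1-yl would keep the low number of compound 3. Also open, on these data alone, is whether a single ring carrying an amine or a carboxylic acid would stay with the single-ring compounds.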